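Leaving the 4-chloropyrimidin-2-yl group on the amine nitrogen

The compounds below may be only part of what the source reports. "The series", "measured", "known", "first", "only" and "open" are said of these compounds alone.

In a functional assay on CWR22R cells (Homo sapiens) for antiproliferative activity, read by CCK-8 assay, with a stated time of 6 days (on this read-out higher numbers stand for weaker inhibition and lower numbers for stronger inhibition), compound 1 `Cc1ccnc(N[C@@H](C)Cn2ccc(-c3ccc(C#N)c(Cl)c3)n2)n1` gives 4760 nM. Compound 2 `C[C@@H](Cn1ccc(-c2ccc(C#N)c(Cl)c2)n1)Nc1nccc(Cl)n1` gives > 30000 nM, which is a limit of the assay and not a number. For compound 2 the only standing available is therefore (the limit of > 30000 nM in this assay, at which 1 of the 2 values shown sits). Within the data shown here, the one measured step is an at least 6.3-fold higher number from compound 1 to compound 2 (0.79 log units; beyond the scatter), beyond the scatter, with chloro in place of methyl on an aromatic carbon.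

Compound 3 `C[C@@H](Cn1ccc(-c2ccc(C#N)c(Cl)c2)n1)Nc1ncnc2nc[nH]c12` changes the group on the amine nitrogen: a group of 9 heavy atoms (5 carbon, 4 nitrogen; one five-membered aromatic ring with 2 hetero atoms, one six-membered aromatic ring with 2 hetero atoms) in place of a group of 7 heavy atoms (4 carbon, 2 nitrogen, 1 chlorine; one six-membered aromatic ring with 2 hetero atoms), on an amine nitrogen. Among the measured compounds shown here, the chloro of compound 2 leaves with the 4-chloropyrimidin-2-yl group, but no measured step covers the exchange of the whole group. The step of an at least 6.3-fold higher number from compound 1 to compound 2 (0.79 log units; beyond the scatter) bears on it only indirectly, and its size is itself bounded by a limit. A move towards lower numbers in this assay is expected, probably of modest size, with compound 1 at 4760 nM as the nearest measured reference. The expected change is an at least 3.0-fold lower number from compound 2 to compound 3 (0.47 log units; beyond the scatter). Compound 3 is estimated at 10000 nM, with an expected range of 2500 nM to 30000 nM.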

Compound 3, half-maximal inhibitory concentration: 4240 nM
The estimate for compound 3 lay 2.4-fold (0.37 log units) above the measured number; measured number inside the range.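

At the amine nitrogen, the poor result with the 4-chloropyrimidin-2-yl group does not extend to every replacement: in this assay, the step is an at least 7.0-fold lower number from compound 2 to compound 3 (0.84 log units; beyond the scatter). The position therefore tolerates the larger group of compound 3, which has a five-membered and a six-membered aromatic ring, while the comparison with the methyl-bearing group of compound 1 gives a 1.1-fold lower number from compound 1 to compound 3 (0.05 log units; within the scatter), so the two groups cannot be told apart in this read-out. Compound 2 stands only as a limit of the assay, so the step to compound 3 has a bound and not an exact size: the limit of > 30000 nM in this assay, at which 1 of the 3 values shown sits.

The compounds shown do not separate the contribution of the five-membered aromatic ring from that of the hydrogen-bond donor counted in the entering group of compound 3. Also open, on these data alone, is how an amino or methoxy group in place of the chloro of the 4-chloropyrimidin-2-yl group would read, and whether any group at this amine nitrogen can move the number beyond the scatter from that of compound 1.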